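Sodium/hydrogen exchanger inhibition: outlook for compound 3

The source may report more compounds than this note shows. Statements on the series, on what has been measured and on what is new or still open speak of the compounds shown alone.

Measured in a functional assay for inhibition of sodium/hydrogen exchanger (Oryctolagus cuniculus); a lower number here means a stronger inhibitor, a higher number a weaker inhibitor:
Compound 1 `CCCc1cc(C)c(C(=O)N=C(N)N)cc1S(C)(=O)=O`: 5.7 nM
Compound 2 `Cc1cc(-n2ccnc2)c(S(C)(=O)=O)cc1C(=O)N=C(N)N`: 23 nM

Compound 2 stands at the higher of the two numbers. Going by the values given here, its only neighbour is compound 1, and the single measured step is a 4.0-fold higher number from compound 1 to compound 2 (0.61 log units; beyond the scatter), a change at the same aromatic carbon that is now altered again.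

Compound 3 `Cc1cc(Oc2cncc(Cl)c2)c(S(C)(=O)=O)cc1C(=O)N=C(N)N` differs from compound 2 as follows: (5-chloropyridin-3-yl)oxy in place of 1H-imidazol-1-yl on an aromatic carbon. Among the compounds with values here, the entering group is not represented in any measured compound, so the only step that bears on this change is the one from compound 1 to compound 2, which shows that substituents at this position move the number by a modest amount while the rest of the structure is kept. A move of similar size in either direction, or none beyond the scatter, is the reasonable expectation; the estimate is placed slightly toward the value of compound 1, since the imidazolyl that carried the higher number is removed.

Compound 3 is expected at 15 nM, with a range of 4 nM to 55 nM. This corresponds to an expected step of a 1.5-fold lower number from compound 2 to compound 3 (0.19 log units; within the scatter).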

Compound 3, half-maximal inhibitory concentration: 14 nM
Beside the measured number, compound 3's estimate is 1.1-fold (0.03 log units) above it; measured number inside the range.
By their numbers in this assay, from the lowest: compound 1; then compounds 3 and 2 (each within the scatter of the next).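

In this assay, going by these compounds alone, this position takes a larger group than the earlier compounds showed: (5-chloropyridin-3-yl)oxy, with 8 heavy atoms and a six-membered aromatic ring, stands in place of 1H-imidazol-1-yl, with 5 heavy atoms and a five-membered aromatic ring, and the step is a 1.6-fold lower number from compound 2 to compound 3 (0.22 log units; within the scatter), so the two groups cannot be told apart here. Within the data shown here, both ring-bearing groups stand apart from propyl, since a 2.5-fold higher number from compound 1 to compound 3 (0.39 log units; beyond the scatter) lies beyond the scatter, as does a 4.0-fold higher number from compound 1 to compound 2 (0.61 log units; beyond the scatter), and across these three compounds propyl gives the lowest number, with no compound going against this. No evidence on the origin of these differences is available.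

Going by these compounds, the oxygen link and the chloropyridine ring enter together, so their separate contributions remain open, and an unsubstituted phenoxy group would be one way to separate them. Also open, on these data alone, is whether a saturated amine such as piperidin-1-yl or a longer alkyl chain at this position would fall nearer compound 1 or the pair of compound 2 and compound 3.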